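Cytotoxicity notes on a bis(trifluoromethyl)benzoyl piperidine carboxanilide series

A few compounds are considered here, and "the series" means these few. Any claim that something is new, unique, unknown or untested is made for them only; others in the source may bear on it.

Measured compounds:
compound 1 `C=CCOc1cccc(NC(=O)C2CCCN(C(=O)c3cc(C(F)(F)F)cc(C(F)(F)F)c3)C2)c1`, 0%
compound 2 `O=C(Nc1cccc(-c2cnco2)c1)C1CCCN(C(=O)c2cc(C(F)(F)F)cc(C(F)(F)F)c2)C1`, 9%
compound 3 `CC(=O)c1cccc(NC(=O)C2CCCN(C(=O)c3cc(C(F)(F)F)cc(C(F)(F)F)c3)C2)c1`, 0%

In an ADME assay on PC-3 cells (Homo sapiens) for cytotoxicity, read by WST assay, tested at 100 uM (a higher number here means more inhibition at the concentration tested (going by the name of the read-out), a lower number less inhibition), compound 3 gives 0%. It stands level with compound 1 at the digits shown, the two together being the lowest of the three numbers; the remaining gap is a number 9 percentage points lower from compound 2 to compound 3 (within the scatter), so all three compounds sit within the scatter of one another.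

Compound 4 `O=C(Nc1ccc(Cl)cc1)C1CCCN(C(=O)c2cc(C(F)(F)F)cc(C(F)(F)F)c2)C1` is not yet measured. Its change from compound 3 is 4-chlorophenyl in place of 3-acetylphenyl on an amide-type nitrogen. Within the data shown here, no measured step alters the group on the amide-type nitrogen itself; the three steps on record, a number 9 percentage points higher from compound 1 to compound 2 (within the scatter), no change at the digits printed from compound 1 to compound 3 (within the scatter) and a number 9 percentage points lower from compound 2 to compound 3 (within the scatter), all vary a group on an aromatic carbon of that same anilide ring, and none of them moves beyond the scatter. Nothing in the series therefore points to a shift in this assay for the incoming 4-chlorophenyl, and compound 4 is expected to show a number 3 percentage points higher from compound 3 to compound 4 (within the scatter), that is, no step beyond the scatter.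

Compound 4 is estimated at 3% in this assay, within a range of -10% to 20%.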

Compound 4, a percentage reported as inhibition, at one concentration (the size of the read-out at that concentration, not a potency): 14%
Estimate against measurement, compound 4: 11 percentage points below, and the stated range covers the measured number.
By their numbers in this assay, from the lowest: compounds 1, 3, 2 and 4 (each within the scatter of the next, the first and the last beyond it).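

Among these compounds, replacing the substituted aryl group on the amide-type nitrogen gives the first steps beyond the scatter in this assay (a number 14 percentage points higher from compound 3 to compound 4 (beyond the scatter); a number 14 percentage points higher from compound 1 to compound 4 (beyond the scatter)), although both are modest and compound 4 still gives only 14% at the tested concentration. The gain is not general across the earlier anilides, as compound 2 stays within the scatter of the new compound (a number 5 percentage points higher from compound 2 to compound 4 (within the scatter)), so 4-chlorophenyl separates only from 3-acetylphenyl and 3-(allyloxy)phenyl. No supporting measurement bears on why this change moves the number.

Each of these steps changes both the substituent and its place on the ring, so the contribution of the chlorine cannot be separated from that of its location. As far as these compounds go, it also remains open how a plain phenyl group, or an amine or a carboxylic acid on that ring, would read in this assay.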